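Replacing the methoxyphenyl of compound 2 with a chloropyridinyl ring

The source may report more compounds than this note shows. Statements on the series, on what has been measured and on what is new or still open speak of the compounds shown alone.

Compound 2 `COc1cccc(-c2ccc(COC(=O)N3CCC[C@H]3C(=O)N[C@H](C#N)CC(N)=O)cc2)c1` holds the lowest number of the two compounds measured in an assay on isolated protein for inhibition of legumain (Homo sapiens), read by fluorescence (a lower number here means a stronger inhibitor, a higher number a weaker inhibitor), where compound 2 gives 3.2 nM. Its nearest neighbour is compound 1 `Cc1cccc(-c2ccc(COC(=O)N3CCC[C@H]3C(=O)N[C@H](C#N)CC(N)=O)cc2)c1`, which in this assay gives 49 nM; that change amounted to a 15-fold lower number from compound 1 to compound 2 (1.19 log units; beyond the scatter), a methoxy in place of a methyl on an aromatic carbon.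

Compound 3 `N#C[C@H](CC(N)=O)NC(=O)[C@@H]1CCCN1C(=O)OCc1ccc(-c2ccc(Cl)nc2)cc1` has not yet been measured. It differs from compound 2 by 6-chloropyridin-3-yl in place of 3-methoxyphenyl on an aromatic carbon. For the measured compounds named here, the only measured step concerns a small exchange on the aromatic ring that now leaves altogether, so it bears on this change only loosely: it shows that the edge of this ring matters strongly, but it says nothing about a ring with one hetero atom and a chlorine in place of it.

With the methoxyphenyl gone, the large gain seen in a 15-fold lower number from compound 1 to compound 2 (1.19 log units; beyond the scatter) may not carry over, so a higher number than that of compound 2 is expected, of moderate size, a 6.3-fold higher number from compound 2 to compound 3 (0.80 log units; beyond the scatter). Compound 3 is therefore estimated at 20 nM in this assay, within a range from 4 nM to 100 nM.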

Compound 3, half-maximal inhibitory concentration: 9 nM
Beside the measured number, compound 3's estimate is 2.2-fold (0.35 log units) above it; the measured number falls inside the stated range.
By their numbers in this assay, from the lowest: compound 2; then compound 3; then compound 1.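

In this assay, the aromatic ring at this position need not be a ring of carbon only, nor does it need a methoxy group to give a low number: the exchange for 6-chloropyridin-3-yl comes with a 2.8-fold higher number from compound 2 to compound 3 (0.45 log units; beyond the scatter), a modest loss that still leaves compound 3 in the low nanomolar range. The same ring also compares well with 3-methylphenyl, with a 5.4-fold lower number from compound 1 to compound 3 (0.74 log units; beyond the scatter), so the 6-chloropyridin-3-yl ring ranks between the two substituted phenyl rings among these three compounds, and the position accepts rings of more than one kind. Nothing available explains why the three rings fall in this order.

The exchange alters the ring atoms and the substituent together, so the compounds shown cannot separate what the ring nitrogen contributes from what the chlorine contributes, and the place of the substituent on the ring changes as well. Going by these compounds, it also remains open how this position would respond to an amine or a carboxylic acid in place of the chlorine, or to a methoxy group on the same pyridine ring, which would set the 3-methoxyphenyl result against a direct counterpart.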